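Changing the nitrogen substituent of compound 3

The compounds below may be only part of what the source reports. "The series", "measured", "known", "first", "only" and "open" are said of these compounds alone.

In a functional assay on MCF7 cells (Homo sapiens) for antiproliferative activity, read by MTT assay, with a stated time of 48 h (on this read-out lower numbers stand for stronger inhibition and higher numbers for weaker inhibition), compound 3 `COc1ccc(-c2c(Nc3ccc(C)c(O)c3)c3ccc(OC)cc3oc2=O)cc1` reads 34400 nM and lies within the scatter of compound 1 `COc1ccc(-c2c(Nc3ccc(F)cc3)c3ccccc3oc2=O)cc1` at 38500 nM while compound 2 `COc1ccc(-c2c(Nc3ccc(C)c(O)c3)c3ccccc3oc2=O)cc1` at 12100 nM gives the lowest number of the three.

Compound 4 `COc1ccc(-c2c(Nc3cccc(C(F)(F)F)c3)c3ccc(OC)cc3oc2=O)cc1` keeps the core of compound 3 and alters only the group on nitrogen (3-(trifluoromethyl)phenyl in place of 3-hydroxy-4-methylphenyl on a nitrogen on an aromatic ring) with 3-(trifluoromethyl)phenyl in place of 3-hydroxy-4-methylphenyl on a nitrogen on an aromatic ring.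

The closest evidence is the earlier change at this same nitrogen, where 3-hydroxy-4-methylphenyl replaced 4-fluorophenyl, a modest step (a 3.2-fold lower number from compound 1 to compound 2 (0.50 log units; beyond the scatter)) on the core without the extra methoxy. Compound 4 gives up that group, which points towards a higher number. The methoxy step (a 2.8-fold higher number from compound 2 to compound 3 (0.45 log units; beyond the scatter)) is also modest, and it shows that the two measured changes do not leave compound 3 below compound 1. Going by the values given here, the methoxy itself stays unchanged here, and no measurement yet shows 3-(trifluoromethyl)phenyl on any core. A small rise is therefore expected, probably not beyond the scatter.

The estimated step is a 1.5-fold higher number from compound 3 to compound 4 (0.16 log units; within the scatter) and its expected direction is upward. In this assay compound 4 is estimated at 50000 nM with an expected range from 20000 nM to 120000 nM as the working figure.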

Compound 4, half-maximal inhibitory concentration: 36200 nM
Compound 4: the middle estimate sits 1.4-fold (0.14 log units) above what was measured; the range from low to high includes it.
By their numbers in this assay, from the lowest: compound 2; then compounds 3, 4 and 1 (each within the scatter of the next).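

In this assay, replacing 3-hydroxy-4-methylphenyl with 3-(trifluoromethyl)phenyl on the core of compound 3 gives a 1.1-fold higher number from compound 3 to compound 4 (0.02 log units; within the scatter) and so leaves the reading within the scatter, even though the entering group has no hydrogen-bond donor or acceptor and has more heavy atoms. The earlier change at this nitrogen, a 3.2-fold lower number from compound 1 to compound 2 (0.50 log units; beyond the scatter) on the core without the extra methoxy, lay beyond the scatter, but it involved a different pair of groups, so the two steps do not isolate an influence of the methoxy. Nothing measured here explains why the reading holds at this position.

Going by these compounds, it remains open whether 3-(trifluoromethyl)phenyl on the core of compound 2 would stay near compound 2 or shift, which would show whether the methoxy alters the response to this change. Also open, on these data alone, is how a phenyl on this nitrogen carrying an amine or a carboxylic acid, or a longer alkyl chain in place of the phenyl, would read in this assay on either core.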